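This account rests on a few compounds, and the source may have more. Where it says the series, first, only, none or still open, it means among the compounds named here.

In a functional assay on HL-60 cells (Homo sapiens) for antiproliferative activity, read by MTT assay, with a stated time of 72 h (on this read-out higher numbers stand for weaker inhibition and lower numbers for stronger inhibition), compound 1 (`COc1ccc(-c2ncnn2-c2cc(OC)c(OC)c(OC)c2)cc1`) gives 120 nM. Compound 2 (`COc1cc(-c2ncnn2-c2ccc(F)cc2)cc(OC)c1OC`) gives > 10000 nM, which is a limit of the assay and not a number. Compound 3 (`COc1cc(-c2ncnn2-c2ccc([N+](=O)[O-])cc2)cc(OC)c1OC`) stands at > 10000 nM, likewise only a limit. Compound 4 (`COc1ccc(-n2ncnc2-c2cc(OC)c(OC)c(OC)c2)cc1`) departs from compound 3 in one place: methoxy in place of nitro on an aromatic carbon. This is methoxy in place of nitro on an aromatic carbon, para to a large group. Among the measured compounds shown here, the only measured step touching that position is a step that the two limits leave unreadable from compound 2 to compound 3, and it offers no size to carry over. Methoxy is also present in compound 1, which reads 120 nM, so a shift towards stronger inhibition in this assay is expected, although the data do not fix its size and the estimate stays wide. The expected change is an at least 12-fold lower number from compound 3 to compound 4 (1.09 log units; beyond the scatter). In this assay the estimated value for compound 4 is 800 nM, with an expected range from 60 nM to 10000 nM.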

Compound 4, half-maximal inhibitory concentration: 6200 nM
For compound 4 the middle estimate is 7.8-fold (0.89 log units) below the measured one, within the range that was stated.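

Of the three groups on this aromatic carbon, methoxy is the only one that gives a readable value in this assay: compound 4 gives 6200 nM. Against nitro the result is an at least 1.6-fold lower number from compound 3 to compound 4 (0.20 log units; that floor lies within the scatter), and against fluoro it is an at least 1.6-fold lower number from compound 2 to compound 4 (0.20 log units; that floor lies within the scatter). Both steps are only floors, and the step between compound 2 and compound 3 cannot be read, because compound 2 and compound 3 each stand at a limit of the assay and not at a number: the limit of > 10000 nM in this assay, at which 2 of the 4 values shown sit.

From the compounds shown here alone, the true size of the gain from methoxy therefore stays open, as does any order between fluoro and nitro at this place. Also open, going by these compounds, is what an amine, a hydroxy group or a longer chain such as ethoxy would give on this aromatic carbon.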